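The compounds below may be only part of what the source reports. "The series", "measured", "known", "first", "only" and "open" are said of these compounds alone.

Compound 1 `CC(=O)Nc1ccc(S(=O)(=O)NNC(=O)c2cccnc2Nc2ccc(Cl)cc2)cc1`: > 100000 nM
Compound 2 `O=C(NNS(=O)(=O)c1ccc(F)cc1)c1cccnc1Nc1ccc(Cl)cc1Cl`: > 100000 nM

Both values come from a functional assay on OVCAR-4 cells (Homo sapiens) for antiproliferative activity; a higher number here means a weaker inhibitor of growth, a lower number a stronger inhibitor of growth. The value of compound 1 is a limit of this assay, not a number. The value of compound 2 is likewise a limit and not a number. For the measured compounds named here, compound 1 thus stands at the limit of > 100000 nM in this assay, at which 2 of the 2 values shown sit; no step between two measured compounds exists in this set, so the measured values give no direction of their own.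

Compound 3 `O=C(NNS(=O)(=O)c1ccc(Cl)cc1Cl)c1cccnc1Nc1ccc(Cl)cc1` is not yet measured. It differs from compound 1 by 2,4-dichlorophenyl in place of 4-acetamidophenyl on a sulfonyl sulfur. Going by the values given here, with no measured step to lean on, the step expected for this change in this assay is a number no higher from compound 1 to compound 3 (the limit leaves the size open), none beyond the scatter, and the outcome is expected most likely to be another limit. Compound 3 is therefore estimated at 100000 nM, with a range from 30000 nM to 300000 nM.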

Compound 3, concentration for total growth inhibition: > 100000 nM
Compound 3 gave a limit, no number; the forecaster's own chance of this, stated with the estimate: 70%; the middle value sits exactly at the limit.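

In this assay compound 3 gives > 100000 nM, a limit and not a number. For the compounds shown here, compound 1 also stands at a limit, so no step between compound 1 and compound 3 can be read. The compounds shown leave open whether any group on the sulfonyl sulfur affects growth inhibition, with all values at one limit: the limit of > 100000 nM in this assay, at which 3 of the 3 values shown sit.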